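The compounds below may be only part of what the source reports. "The series", "measured", "known", "first", "only" and "open" are said of these compounds alone.

Compound 1 `CCC(=O)N1CCC(NC(=O)Nc2ccc(C(F)(F)F)c(F)c2)CC1` gives 3.9 ug/mL in a physicochemical assay for solubility, read by mass spectrometry, in phosphate buffer, with a stated time of 24 h, at pH 7.4; a lower number here means a less soluble compound, a higher number a more soluble compound. Compound 2 `CCC(=O)N1CCC(NC(=O)Nc2ccc(OC(F)(F)F)c(F)c2)CC1`, which carries trifluoromethoxy in place of trifluoromethyl on an aromatic carbon, gives 11 ug/mL in this assay, so the change brings a 2.8-fold higher number from compound 1 to compound 2 (0.45 log units; beyond the scatter). Compound 3 `O=C(Nc1ccc(C(F)(F)F)c(F)c1)NC1CCN(C(=O)[C@@H]2CCOC2)CC1` differs from compound 1 by oxolan-3-yl in place of ethyl on a carbonyl carbon; in this assay compound 3 gives 1.9 ug/mL, a step of a 2.1-fold lower number from compound 1 to compound 3 (0.31 log units; beyond the scatter); compound 3 thus holds the lowest of the three numbers measured.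

Compound 4 `O=C(Nc1ccc(OC(F)(F)F)c(F)c1)NC1CCN(C(=O)[C@@H]2CCOC2)CC1` has not been measured. It stands to compound 3 as compound 2 stands to compound 1: the change is trifluoromethoxy in place of trifluoromethyl on an aromatic carbon, with the surroundings of the place the same in both pairs, so this is the same change made on the core of compound 3, where the two cores differ by oxolan-3-yl in place of ethyl on a carbonyl carbon.

The step for compound 4 is expected to resemble the earlier one, a 2.8-fold higher number from compound 3 to compound 4 (0.45 log units; beyond the scatter) against a 2.8-fold higher number from compound 1 to compound 2 (0.45 log units; beyond the scatter), resting on a single measured pair only. Starting from compound 3 at 1.9 ug/mL, compound 4 is estimated at 5.3 ug/mL in this assay. The expected range for compound 4 runs from 2.5 ug/mL to 11 ug/mL.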

Compound 4, solubility: 61 ug/mL
For compound 4 the middle estimate is 12-fold (1.06 log units) below the measured one; measured number outside the range, above it.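

In this assay, trifluoromethoxy in place of trifluoromethyl gives a higher number with either group on the carbonyl carbon: with oxolan-3-yl the change brings a 32-fold higher number from compound 3 to compound 4 (1.51 log units; beyond the scatter), and with ethyl it brings a 2.8-fold higher number from compound 1 to compound 2 (0.45 log units; beyond the scatter), so the direction carries over from one core to the other while the size does not. Read the other way, oxolan-3-yl in place of ethyl gives a 2.1-fold lower number from compound 1 to compound 3 (0.31 log units; beyond the scatter) with trifluoromethyl on the aromatic carbon but a 5.5-fold higher number from compound 2 to compound 4 (0.74 log units; beyond the scatter) with trifluoromethoxy there, so the two changes do not add independently in these four compounds. This is one set of four compounds and supplies no general rule for other cores, and nothing available accounts for the difference in size.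

From the compounds shown here alone, it remains open whether the same change gives a step of similar size with a longer chain on the carbonyl carbon, or with a group carrying an amine or a carboxylic acid there. Also open, going by these compounds, is how the step behaves with the other stereoisomer of the oxolan-3-yl group.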